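Swapping pyridin-4-yl for 4-chlorophenyl at the edge of the assay

A few compounds are considered here, and "the series" means these few. Any claim that something is new, unique, unknown or untested is made for them only; others in the source may bear on it.

Compound 1 (`COc1ccc(-c2noc(-c3ccncc3)n2)cc1OC1CCCC1`) offers no true number to start from. In a functional assay on PC-3 cells (Homo sapiens) for antiproliferative activity, read by MTT assay, with a stated time of 24 h (on this read-out higher numbers stand for weaker inhibition and lower numbers for stronger inhibition), compound 1 gives > 1000000 nM as a limit of the assay and not as a measured value. Compound 2 (`COc1ccc(-c2noc(Cc3c[nH]c4ccccc34)n2)cc1OC1CCCC1`) gives > 1000000 nM and this too is a limit. Compound 3 (`Fc1ccc(-c2nc(-c3ccccc3)no2)cc1`) gives > 1000000 nM and this is again a limit. Everything known so far therefore comes down to the limit of > 1000000 nM in this assay, at which 3 of the 3 values shown sit, and no measured pair shows how a structural change moves the read-out.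

The next compound is compound 4 (`COc1ccc(-c2noc(-c3ccc(Cl)cc3)n2)cc1OC1CCCC1`), which keeps the core of compound 1 and changes one group. The difference is 4-chlorophenyl in place of pyridin-4-yl on an aromatic carbon and it places 4-chlorophenyl in place of pyridin-4-yl on an aromatic carbon.

Among the measured compounds shown here, with no measured step to lean on, any forecast is loose. It rests on compound 1 with its limit of > 1000000 nM and on the fact that a result can only be reported on one side of that limit. Compound 4 may well stay at the same limit, and any measurable result would mean stronger inhibition in this assay. The expected change is an at least 3.3-fold lower number from compound 1 to compound 4 (0.52 log units; beyond the scatter) and it is a rough estimate. Compound 4 is estimated at 300000 nM with an expected range from 30000 nM to 1000000 nM as its likely span.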

Compound 4, half-maximal inhibitory concentration: > 1000000 nM
Compound 4 gave a limit, no number; the forecaster's own chance of this, stated with the estimate: 55%; middle value at least 3.3-fold (0.52 log units) away from the limit.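

In this assay compound 4 gives > 1000000 nM as a limit and not as a number. Compound 1 also stands at a limit, so the step from 4-chlorophenyl in place of pyridin-4-yl between compound 1 and compound 4 cannot be read. The compounds shown leave open which structural change, if any, would give a measurable value, since every result sits at one boundary: the limit of > 1000000 nM in this assay, at which 4 of the 4 values shown sit.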